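A few compounds are considered here, and "the series" means these few. Any claim that something is new, unique, unknown or untested is made for them only; others in the source may bear on it.

In a functional assay on U-251 cells (Homo sapiens) for inhibition, read by MTT assay, with a stated time of 48 h (on this read-out lower numbers stand for stronger inhibition and higher numbers for weaker inhibition), three compounds have been measured so far. Compound 1 `C#CCN(C)CCCOc1cc(NCc2ccc(/C=C/C(=O)NO)cc2)ccc1Cl` gives 3240 nM in this test, and compound 3 `C#CCN(C)CCCOc1ccc(NC(=O)CCCCCCC(=O)NO)cc1Cl` gives 2830 nM in the same test, two values that lie within the usual scatter of each other. Compound 2 `C#CCN(C)CCCOc1cc(NC(=O)CCCCCCCCC(=O)NO)ccc1Cl` has the highest number of the three at 33200 nM and is the weakest inhibitor here, with both other compounds lower by a margin beyond the scatter.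

Compound 4 `C#CCN(C)CCCOc1cc(NC(=O)CCCCCCC(=O)NO)ccc1Cl` has not yet been measured. It differs from compound 2 only in the chain: hydroxycarbamoyl in place of 2-(hydroxycarbamoyl)ethyl on a saturated chain carbon, six bonds along the chain from a carbonyl carbon with hydroxycarbamoyl in place of 2-(hydroxycarbamoyl)ethyl on a saturated chain carbon, six bonds along the chain from a carbonyl carbon. Among the compounds with values here, no measured pair shows this change alone, so any expectation rests on an indirect comparison. Compound 4 keeps the core of compound 2 but ends in the same chain as compound 3, which gives 2830 nM on a differently arranged core. A lower number is therefore expected, and the estimated step of a 6.6-fold lower number from compound 2 to compound 4 (0.82 log units; beyond the scatter) would lie beyond the scatter, toward stronger inhibition. For compound 4 the estimate is 5000 nM with 1800 nM to 15000 nM as the expected range.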

Compound 4, half-maximal inhibitory concentration: 120 nM
For compound 4 the middle estimate is 42-fold (1.62 log units) above the measured one; the whole stated range lies above it.
By their numbers in this assay, from the lowest: compound 4; then compounds 3 and 1 (each within the scatter of the next); then compound 2.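

In this assay, the step of a 280-fold lower number from compound 2 to compound 4 (2.44 log units; beyond the scatter) comes from hydroxycarbamoyl in place of 2-(hydroxycarbamoyl)ethyl on a saturated chain carbon, six bonds along the chain from a carbonyl carbon, with the core unchanged. Within the data shown here, the earlier compounds offered no pair differing in one place, so this is the first direct sign that the response on this core depends strongly on chain length, with the shorter chain of compound 4 giving the lower number and the hydrogen-bond donor and acceptor counts of the two exchanged groups staying the same. Nothing available accounts for a step of this size, and the pair shows only that it occurs, not how it arises.

With only these two chain lengths shown on this core, it remains open whether the number changes gradually or abruptly between them, and whether a still shorter chain would lower it further or raise it again. On these data alone, it is also open whether the chain end matters as much as the length, as a carboxylic acid in place of the hydroxycarbamoyl group on the chain of compound 4 would test.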